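Adding a carbonyl to the sulfur side chain

The source may report more compounds than this note shows. Statements on the series, on what has been measured and on what is new or still open speak of the compounds shown alone.

Values in a functional assay on HCT-116 cells (Homo sapiens) for inhibition, read by MTT assay, with a stated time of 48 h; a higher number here means a weaker inhibitor, a lower number a stronger inhibitor:
- compound 1 `COc1ccc(-n2c(SC)nnc2-c2cc(OC)c(OC)c(OC)c2)cc1`: > 60000 nM, a limit of the assay
- compound 2 `COc1ccc(-n2c(SCc3ccccc3)nnc2-c2cc(OC)c(OC)c(OC)c2)cc1`: 42400 nM
- compound 3 `COc1ccc(CSc2nnc(-c3cc(OC)c(OC)c(OC)c3)n2-c2ccc(OC)cc2)cc1`: 49600 nM

In this assay, for the measured compounds named here, compound 3 gives 49600 nM, the higher of the two true numbers, but its only measured comparison is with compound 2, and that step is a 1.2-fold higher number from compound 2 to compound 3 (0.07 log units; within the scatter). The two therefore stand level. Compound 1 gives only a limit, > 60000 nM.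

Compound 4 `COc1ccc(C(=O)CSc2nnc(-c3cc(OC)c(OC)c(OC)c3)n2-c2ccc(OC)cc2)cc1` keeps the shared core of compound 3 and alters the side chain: (4-methoxyphenyl)carbonyl in place of 4-methoxyphenyl on a saturated chain carbon bound to a sulfur. In words, (4-methoxyphenyl)carbonyl stands in place of 4-methoxyphenyl on a saturated chain carbon bound to a sulfur.

Going by the values given here, no measured step makes this exact change. The closest evidence comes from changes at the same chain carbon, an at least 1.4-fold lower number from compound 1 to compound 2 (0.15 log units; that floor lies within the scatter) and an at least 1.2-fold lower number from compound 1 to compound 3 (0.08 log units; that floor lies within the scatter), while the methoxy change on the aromatic ring gave a 1.2-fold higher number from compound 2 to compound 3 (0.07 log units; within the scatter). None of these steps shows a change beyond the scatter, so no step beyond the scatter is expected in this assay. The expected step is a 1.4-fold lower number from compound 3 to compound 4 (0.15 log units; within the scatter). Compound 4 is estimated at 35000 nM, with an expected range from 10000 nM to 60000 nM.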

Compound 4, half-maximal inhibitory concentration: > 60000 nM
Compound 4: a limit, no number; the forecaster's own chance of this, stated with the estimate: 25%; at least 1.7-fold (0.23 log units) between middle value and limit.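

In this assay, the carbonyl change gives an at least 1.2-fold higher number from compound 3 to compound 4 (0.08 log units; that floor lies within the scatter), and the comparison with the unsubstituted phenyl side chain gives an at least 1.4-fold higher number from compound 2 to compound 4 (0.15 log units; that floor lies within the scatter); these are floors only, so neither step shows a change beyond the scatter, and the step between the two compounds that both read as limits cannot be read. For the compounds shown here, compound 4 gives > 60000 nM, which is a limit and not a number, so the true size of its steps stays unknown, and this reading is shared with one other compound: the limit of > 60000 nM in this assay, at which 2 of the 4 values shown sit. The earlier compounds left open whether an aromatic ring on the side chain was enough to give a true number in this assay, and compound 4 shows that it is not, since it carries such a ring yet gives only a limit.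

The compounds shown leave open whether any change at this chain carbon can move the number beyond the scatter. An amine, a carboxylic acid or a longer chain between the carbonyl and the sulfur could test this, and none of them stands among these compounds.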